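Compound 1 to compound 4: methyl in place of methoxy

The source may report more compounds than this note shows. Statements on the series, on what has been measured and on what is new or still open speak of the compounds shown alone.

For the measured compounds named here, in a functional assay (Mus musculus) for inhibition, read by cell counting, with a stated time of 3 days (a higher number here means a weaker inhibitor, a lower number a stronger inhibitor), compound 1 `COc1ccc(N(C)c2nc(C)nc3c2nc(C)n3C)cc1` gives 8700 nM, the only actual number. Compound 2 `COc1ccc(Nc2nc(C)nc3c2nc(C)n3C)cc1` is reported only as a limit, >= 100000 nM. Compound 3 `COc1cccc(N(C)c2nc(C)nc3c2nc(C)n3C)c1` is an isomer of compound 1 with its methoxy placed differently. Compound 3 is also reported only as a limit, >= 100000 nM. The series therefore rests largely on (the limit of >= 100000 nM in this assay, at which 2 of the 3 values shown sit).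

Compound 4 `Cc1ccc(N(C)c2nc(C)nc3c2nc(C)n3C)cc1` changes one place in compound 1: methyl in place of methoxy on an aromatic carbon. It has methyl in place of methoxy on an aromatic carbon, para to a large group.

Going by the values given here, no measured step covers this exact change. The nearest is an at least 11-fold higher number from compound 1 to compound 2 (1.06 log units; beyond the scatter), a large step at a nitrogen rather than at the aromatic carbon, so it bears only indirectly. It does show that compound 1 can lose its measurable value through one small change. With compound 3 also ending at a limit, any departure from compound 1 is expected to move towards a higher number in this assay, though probably by less than that large step.

The expected change is a 3.4-fold higher number from compound 1 to compound 4 (0.54 log units; beyond the scatter). For compound 4 the estimated value is 30000 nM, with an expected range of 7000 nM to 100000 nM.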

Compound 4, half-maximal inhibitory concentration: > 100000 nM
Compound 4: only a limit was reported; the forecaster's own chance of this, stated with the estimate: 35%; middle value at least 3.3-fold (0.52 log units) from the limit.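

In this assay, for the compounds shown here, replacing the methoxy on the aromatic carbon para to a large group gives the first direct evidence on this place: an at least 11-fold higher number from compound 1 to compound 4 (1.06 log units; beyond the scatter), a large step. Compound 4 is reported only as a limit, > 100000 nM, so this step has a lower bound and no upper end. With compound 3, which keeps the methoxy but places it differently, the methoxy as placed in compound 1 is the only arrangement on this ring shown with a measured number, and the other compounds stay at limits: the limit of >= 100000 nM in this assay, at which 2 of the 4 values shown sit.

Going by these compounds, whether any other group on this aromatic carbon, such as an ethoxy, a hydroxyl or an amine, would keep a measurable value in this assay remains open. With one actual number in the series, compound 2, compound 3 and compound 4 cannot be placed in order, and how far each lies from compound 1 cannot be stated beyond its limit.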